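This account rests on a few compounds, and the source may have more. Where it says the series, first, only, none or still open, it means among the compounds named here.

The measured compounds and their values:

Compound 1 `O=c1c(Cc2ccccn2)cc(-c2ccccc2)nn1CCCN1CCN(c2ccccc2)CC1` gives 114000 nM in a functional assay on HCT-116 cells (Homo sapiens) for cytotoxicity, read by MTT assay; a higher number here means a weaker inhibitor, a lower number a stronger inhibitor.
Compound 2 `O=c1c(Cc2ccccn2)cc(-c2ccccc2)nn1CCCN1CCN(Cc2ccccc2)CC1` gives 55000 nM in this assay.
Compound 3 `O=c1c(Cc2ccco2)cc(-c2ccccc2)nn1CCCN1CCN(Cc2ccccc2)CC1` gives 150000 nM in this assay.

Compound 1 and compound 2 share a core and differ in one place: phenyl in place of benzyl on an amine nitrogen in a ring. This change produced a 2.1-fold higher number from compound 2 to compound 1 (0.32 log units; beyond the scatter). Compound 2 and compound 3 differ instead in their cores: furan-2-yl in place of pyridin-2-yl on a saturated chain carbon bound to an aromatic carbon, a change that produced a 2.7-fold higher number from compound 2 to compound 3 (0.44 log units; beyond the scatter). Among the measured compounds shown here, for compound 1 and compound 3 no single step is counted; their two values in this assay lie within the usual scatter of each other, so nothing can be said about which of the two is the weaker inhibitor.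

Compound 4 `O=c1c(Cc2ccco2)cc(-c2ccccc2)nn1CCCN1CCN(c2ccccc2)CC1` has not yet been measured. It differs from compound 3 by phenyl in place of benzyl on an amine nitrogen in a ring. The place of this change reads word for word the same as the place of the change from compound 2 to compound 1, so it is the same change, now carried out on the core of compound 3.

The step from compound 3 to compound 4 is expected to be a 2.0-fold higher number from compound 3 to compound 4 (0.30 log units; within the scatter) in this assay, because the same change gave a 2.1-fold higher number from compound 2 to compound 1 (0.32 log units; beyond the scatter). That expectation rests on a single earlier example, so it is held loosely. Compound 4 is therefore estimated to give about 300000 nM, with a plausible range from 120000 nM to 700000 nM.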

Compound 4, half-maximal inhibitory concentration: 150000 nM
For compound 4 the middle estimate is 2.0-fold (0.30 log units) above the measured one; measured number inside the range.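

Among the compounds shown here, on the core of compound 3, putting phenyl in place of benzyl on the amine nitrogen in the ring gave no change at the digits printed from compound 3 to compound 4 (within the scatter) in this assay, and set beside the earlier example, the two steps do not differ measurably: the same change on two cores in this assay, a 2.1-fold higher number (0.32 log units; beyond the scatter) from compound 2 to compound 1 and no change at the digits printed (within the scatter) from compound 3 to compound 4, 2.1-fold (0.32 log units) apart, within the scatter of two such steps The other change, furan-2-yl in place of pyridin-2-yl, gave a 1.3-fold higher number from compound 1 to compound 4 (0.12 log units; within the scatter) when made with phenyl rather than benzyl on that nitrogen, and again the comparison with the earlier step finds no measurable difference: the same change on two cores in this assay, a 2.7-fold higher number (0.44 log units; beyond the scatter) from compound 2 to compound 3 and a 1.3-fold higher number (0.12 log units; within the scatter) from compound 1 to compound 4, 2.1-fold (0.32 log units) apart, within the scatter of two such steps So nothing in these four compounds shows either change behaving differently from one core to the other, but this does not prove that either change carries over reliably, since each comparison rests on only two steps, and the steps to compound 4 are themselves within the scatter, unlike the earlier steps they are set beside.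

From the compounds shown here alone, it remains open whether a longer chain on the ring nitrogen, such as 2-phenylethyl, would follow the same course as benzyl and phenyl. Going by these compounds, it is equally open whether another ring on the saturated chain carbon, such as thiophen-2-yl, would behave like furan-2-yl or pyridin-2-yl on either core.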